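Methyl for Hydrogen on Two Cores: Growth Inhibition Compared

The source may hold more compounds than are shown below. What is called first, only, known or untested is meant among the compounds shown, and "the series" means these compounds.

Three compounds have been measured in a functional assay on HCT-116 cells (Homo sapiens) for antiproliferative activity, read by MTT assay, with a stated time of 72 h; a higher number here means a weaker inhibitor of growth, a lower number a stronger inhibitor of growth:

compound 1 `Cn1nc(-c2ccnc(Nc3cccc([N+](=O)[O-])c3)n2)c2ccccc21` gives 490 nM
compound 2 `CCn1nc(-c2ccnc(Nc3cccc([N+](=O)[O-])c3)n2)c2ccccc21` gives 2820 nM
compound 3 `Cc1nn(-c2ccnc(Nc3ccc(S(N)(=O)=O)cc3)n2)c2ncccc12` gives 8840 nM

Compound 1 and compound 2 share a core and differ in one place: methyl in place of hydrogen on a saturated chain carbon bound to an aromatic nitrogen. That change produced a 5.8-fold higher number from compound 1 to compound 2 (0.76 log units; beyond the scatter). Compound 3 stands on a different core; the difference between the two cores is not broken down here. In this assay compound 3 gives the highest number of the three, and its nearest neighbour is compound 2.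

Compound 4 `CCc1nn(-c2ccnc(Nc3ccc(S(N)(=O)=O)cc3)n2)c2ncccc12` has not yet been measured. It differs from compound 3 as follows: methyl in place of hydrogen on a saturated chain carbon bound to an aromatic carbon. Within the data shown here, this is the same kind of change as the one from compound 1 to compound 2, but not the same: there the saturated chain carbon is bound to an aromatic nitrogen, here it is bound to an aromatic carbon, and the surrounding core is different. Only one measured example of this kind of change exists among these compounds, so any expectation rests on a single step. The step from compound 1 to compound 2 was modest but beyond the scatter, and the account expects the step from compound 3 to compound 4 in this assay to be in the same direction and of a similar or somewhat smaller size, a 2.5-fold higher number from compound 3 to compound 4 (0.40 log units; beyond the scatter). For compound 4 the estimated value is 22000 nM, with a range from 7000 nM to 70000 nM.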

Compound 4, concentration for 50% growth inhibition: 6340 nM
Estimate against measurement, compound 4: 3.5-fold (0.54 log units) above; measured number below the stated range.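

In this assay, methyl in place of hydrogen on a saturated chain carbon bound to an aromatic carbon gave a 1.4-fold lower number from compound 3 to compound 4 (0.14 log units; within the scatter), so this methyl to ethyl change leaves compound 3 and compound 4 indistinguishable in growth inhibition. Set beside the earlier step, the result shows that the effect of this kind of change did not carry over from one core to the other in this series: the same change on two cores in this assay, a 5.8-fold higher number (0.76 log units; beyond the scatter) from compound 1 to compound 2 and a 1.4-fold lower number (0.14 log units; within the scatter) from compound 3 to compound 4, 8.0-fold (0.90 log units) apart, beyond the scatter of two such steps What this does not show is the reason for the difference, since the two steps differ both in the core and in the atom that bears the chain, an aromatic nitrogen in one case and an aromatic carbon in the other, and a single step on each core cannot separate these two differences or support a rule for any further core.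

The compounds shown leave open whether a longer chain, such as propyl, would widen the difference between the two cores or leave the core of compound 3 as flat as this single step suggests. They also leave open how a hydroxyl or an amine on the end of the ethyl chain would read on either core.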